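Swapping the aromatic ring on the amide carbonyl

The compounds below may be only part of what the source reports. "The series", "measured", "known", "first", "only" and "open" are said of these compounds alone.

Measured so far in a functional assay on the whole organism (blood) with Rattus norvegicus as the target, with stated times of 24 h and 1 h, at a dose of 1 mg/kg by the intraperitoneal route; a lower number here means a weaker effect, a higher number a stronger effect of the compound at the dose given:
compound 1, `COc1ccc(Cl)cc1C(=O)NCCC1CCN(S(=O)(=O)NC(=O)NC2CCCCC2)CC1`, gives 39%.
compound 2, `COc1ncccc1C(=O)NCCC1CCN(S(=O)(=O)NC(=O)NC2CCCCC2)CC1`, gives 22%.
compound 3, `O=C(NC[C@@H]1C[C@@H]2C=C[C@@H]1C2)NS(=O)(=O)N1CCC(CCNC(=O)c2cc(Cl)ccn2)CC1`, gives 16%.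

Compound 3 has the lowest of the three numbers. Its nearest neighbour is compound 2, whose number lies within the usual scatter of it, so the two cannot be ranked against each other; compound 1 stands beyond the scatter above compound 3.

Compound 4, `Cn1cccc(C(=O)NCCC2CCN(S(=O)(=O)NC(=O)NC[C@@H]3C[C@@H]4C=C[C@@H]3C4)CC2)c1=O`, has not yet been measured. It differs from compound 3 in one place: a group of 8 heavy atoms (6 carbon, 1 nitrogen, 1 oxygen; one six-membered aromatic ring with 1 hetero atom) in place of a group of 7 heavy atoms (5 carbon, 1 nitrogen, 1 chlorine; one six-membered aromatic ring with 1 hetero atom), on a carbonyl carbon. Going by the values given here, one measured step bears on this, since it also exchanges the aromatic ring on the carbonyl carbon: a number 17 percentage points lower from compound 1 to compound 2 (beyond the scatter). In that step the ring lost its chlorine and took up a ring nitrogen, and the number fell modestly. The change from compound 3 to compound 4 likewise removes a chlorine while adding an oxygen to the ring. A small downward step, or none beyond the scatter, is therefore expected, as a number 4 percentage points lower from compound 3 to compound 4 (within the scatter). Compound 4 is expected to give 12%, with a range from 3% to 28%.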

Compound 4, a percentage reported as activity, at one dose (the size of the read-out at that dose, not a potency): 19%
Compound 4: middle estimate off by 7 percentage points, on the low side; measured number inside the range.
By their numbers in this assay, from the lowest: compounds 3, 4 and 2 (each within the scatter of the next); then compound 1.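

In this assay, the exchange of the 4-chloropyridin-2-yl group for the ring of compound 4 gives a number 3 percentage points higher from compound 3 to compound 4 (within the scatter), so on this core the chlorine can leave the ring on the carbonyl carbon without a change that can be told from scatter. Going by these compounds alone, this differs from a number 17 percentage points lower from compound 1 to compound 2 (beyond the scatter), where a ring exchange that also removed a chlorine came with a step beyond the scatter, so the one earlier step does not carry over as a general rule to this other core. Nothing measured here gives a reason for either outcome.

The compounds shown leave open whether the 5-chloro-2-methoxyphenyl ring of compound 1 would give a higher number on the core of compound 3. They also leave open how a plain phenyl ring, or a ring carrying an amine or a carboxylic acid, would read on this carbonyl carbon.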